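This account rests on a few compounds, and the source may have more. Where it says the series, first, only, none or still open, it means among the compounds named here.

Compound 1 `Cc1ccc(OCC(=O)N(Cc2cccs2)c2nccs2)cc1`: 2240 nM
Compound 2 `CCCN(Cc1cccs1)C(=O)COc1ccc(C)cc1`: 40 nM
Compound 3 `Cc1ccc(OCC(=O)N(Cc2cccs2)c2cnn(C)c2)cc1`: 63000 nM

Among these three, compound 3 gives the highest number in an assay on HEK293 cells for agonist activity at transient receptor potential cation channel subfamily M member 8 (Homo sapiens), read by fluorescence and calcium flux, with a stated time of 15 min (on this read-out higher numbers stand for an effect only at larger amounts of compound and lower numbers for an effect already at smaller amounts), so it needs the largest amount to act; the step of a 28-fold higher number from compound 1 to compound 3 (1.45 log units; beyond the scatter) and the step of a 1600-fold higher number from compound 2 to compound 3 (3.20 log units; beyond the scatter) set it apart from both others. Compound 4 `Cc1ccc(OCC(=O)N(Cc2cccs2)c2ccon2)cc1` differs from compound 3 in one place: 1,2-oxazol-3-yl in place of 1-methyl-1H-pyrazol-4-yl on an amide-type nitrogen. Among the measured compounds shown here, no measured step swaps one such ring for another of this kind at this nitrogen, but the step of a 28-fold higher number from compound 1 to compound 3 (1.45 log units; beyond the scatter) shows that a change of ring there alone moves the number a great deal, and the step of a 56-fold lower number from compound 1 to compound 2 (1.75 log units; beyond the scatter) shows this nitrogen carries even larger shifts. For compound 4 a fall is expected, about a 13-fold lower number from compound 3 to compound 4 (1.10 log units; beyond the scatter). Compound 4 is estimated at 5000 nM, with a range from 800 nM to 40000 nM.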

Compound 4, half-maximal effective concentration: 2 nM
Estimate against measurement, compound 4: 2500-fold (3.40 log units) above, outside the stated range (below it).
By their numbers in this assay, from the lowest: compound 4; then compound 2; then compound 1; then compound 3.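

In this assay, among the compounds shown here, the choice of ring on this amide-type nitrogen matters far more than the earlier compounds showed: a 32000-fold lower number from compound 3 to compound 4 (4.50 log units; beyond the scatter) separates two five-membered aromatic rings, each with 2 hetero atoms, so these counts alone do not set the number. Both earlier rings gave higher numbers than propyl, but 1,2-oxazol-3-yl reverses that order, with a 20-fold lower number from compound 2 to compound 4 (1.30 log units; beyond the scatter) and also a 1100-fold lower number from compound 1 to compound 4 (3.05 log units; beyond the scatter) in the swap from 1,3-thiazol-2-yl. No available evidence explains these differences. Still open, as far as these compounds go, is how a phenyl ring or a butyl chain on this nitrogen would compare with 1,2-oxazol-3-yl.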